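Carbonyl substituent notes: compound 3 to compound 4

The compounds below may be only part of what the source reports. "The series", "measured", "known", "first", "only" and "open" are said of these compounds alone.

Measured in an ADME assay for protein binding, using equilibrium dialysis, at pH 7.4, tested at 2 uM; a higher number here means a larger unbound share of the compound, a lower number a smaller unbound share:
compound 1 `CC1CC=C(C(=O)N(c2cc(C#CC(C)(C)C)sc2C(=O)O)C(C)C)CC1` (0.08)
compound 2 `CC(C)N(C(=O)C1CCC(F)(F)CC1)c1cc(C#CC(C)(C)C)sc1C(=O)O` (0.4)
compound 3 `CC(C)N(C(=O)[C@H]1[C@@H]2CCCC[C@@H]21)c1cc(C#CC(C)(C)C)sc1C(=O)O` (0.04)

Compound 3 (0.04) stands within the scatter of compound 1 (0.08), as the step between them shows (a 2.0-fold lower number from compound 1 to compound 3 (0.30 log units; within the scatter)). Compound 2 (0.4) stands clearly apart from both.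

Compound 4 `CC(C)N(c1cc(C#CC(C)(C)C)sc1C(=O)O)C(=O)[C@H]1CC[C@H](Cl)CC1` has not yet been measured. Its difference from compound 3 is a group of 7 heavy atoms (6 carbon, 1 chlorine; one six-membered non-aromatic ring of carbon only) in place of a group of 7 heavy atoms (7 carbon; one three-membered non-aromatic ring of carbon only, one six-membered non-aromatic ring of carbon only), on a carbonyl carbon (on a carbonyl carbon), and the group that enters is 4-chlorocyclohexyl.

Going by the values given here, three measured steps bear on this change. The two halogen-free groups show no separation (a 2.0-fold lower number from compound 1 to compound 3 (0.30 log units; within the scatter)). Among the compounds with values here, the only halogen-bearing group so far, the 4,4-difluorocyclohexyl of compound 2, gives the two steps beyond the scatter (a 5.0-fold higher number from compound 1 to compound 2 (0.70 log units; beyond the scatter) and a 10-fold lower number from compound 2 to compound 3 (1.00 log units; beyond the scatter)). No chlorine-bearing group has been measured, and three compounds offer a thin basis, so the transfer from compound 2 is uncertain. A step in the same direction as the rise to compound 2 is expected, but only a fraction of its size, and a step within the scatter remains possible.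

The expected step is a 2.5-fold higher number from compound 3 to compound 4 (0.40 log units; beyond the scatter) (an estimate).

The estimated value for compound 4 is 0.1 (expected range 0.04 to 0.25).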

Compound 4, unbound fraction: 0.14
Estimate against measurement, compound 4: 1.4-fold (0.15 log units) below; measured number inside the range.
By their numbers in this assay, from the lowest: compounds 3, 1 and 4 (each within the scatter of the next, the first and the last beyond it); then compound 2.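

In this assay, 4-chlorocyclohexyl on this carbonyl carbon stands apart from the carbon-only group of compound 3 (a 3.5-fold higher number from compound 3 to compound 4 (0.54 log units; beyond the scatter)), so a second halogen-bearing group now separates from that group, as 4,4-difluorocyclohexyl did. The two halogen-bearing groups are not interchangeable at this position, since replacing 4,4-difluorocyclohexyl with 4-chlorocyclohexyl is itself a step beyond the scatter (a 2.9-fold lower number from compound 2 to compound 4 (0.46 log units; beyond the scatter)). Against 4-methylcyclohex-1-en-1-yl, however, the same group shows no separation (a 1.8-fold higher number from compound 1 to compound 4 (0.24 log units; within the scatter)), so compound 1 goes against any reading in which a halogen-bearing group stands clear of every halogen-free one.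

No measurement available here accounts for these differences. The compounds shown leave open where 4-fluorocyclohexyl and 4,4-dichlorocyclohexyl would fall in this order, which would help separate the kind of halogen from the number of halogen atoms on the ring, and where an unsubstituted cyclohexyl group or a 4-aminocyclohexyl group would fall.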